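This account rests on a few compounds, and the source may have more. Where it says the series, first, only, none or still open, it means among the compounds named here.

For the measured compounds named here, compound 1 `O=C(/C=C/c1ccccc1OC(=O)c1ccccc1)NOC(=O)N1CCOCC1` is one of three compounds measured in a functional assay on HCT-116 cells (Homo sapiens) for inhibition, read by ELISA, with a stated time of 24 h (a higher number here means a weaker inhibitor of growth, a lower number a stronger inhibitor of growth), where compound 1 gives 12500 nM. Compound 3 `O=C(/C=C/c1ccccc1O)NO`, which carries a free hydroxyl on the ring and a plain hydroxamic acid, gives 16800 nM, and compound 2 `CC(=O)ONC(=O)/C=C/c1ccccc1OC(=O)c1ccccc1` gives 21300 nM. All three numbers lie within the usual scatter of one another, so none of the three can be set apart from the others on this evidence.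

Going by the values given here, the only step measured so far between two compounds that differ in one place is a 1.7-fold higher number from compound 1 to compound 2 (0.23 log units; within the scatter), a swap of methyl for morpholin-4-yl on the carbonyl carbon attached to the oxygen of the hydroxamate.

Compound 4 `O=C(/C=C/c1ccccc1OC(=O)c1ccccc1)NOC(=O)c1ccccc1` differs from compound 1 at exactly that carbonyl carbon: phenyl in place of morpholin-4-yl on a carbonyl carbon. The step from compound 1 to compound 2 bears directly on this change, since it alters the same position, and it stayed within the scatter. With nothing else to go on, a replacement of morpholin-4-yl by phenyl at this place is therefore expected to leave the number close to where compound 1 sits, giving an estimated 1.0-fold higher number from compound 1 to compound 4 (0.02 log units; within the scatter). For compound 4 in this assay the expected value is 13000 nM, with a range from 5000 nM to 35000 nM.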

Compound 4, concentration for 50% growth inhibition: 13600 nM
For compound 4 the middle estimate is 1.0-fold (0.02 log units) below the measured one, and the stated range covers the measured number.
By their numbers in this assay, from the lowest: compounds 1, 4, 3 and 2 (each within the scatter of the next).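

In this assay, the step to phenyl gives a 1.1-fold higher number from compound 1 to compound 4 (0.04 log units; within the scatter), so this carbonyl carbon accepts an aromatic carbon ring in place of the non-aromatic morpholin-4-yl ring without a difference that can be read. Phenyl against methyl gives a 1.6-fold lower number from compound 2 to compound 4 (0.19 log units; within the scatter), which adds a second comparison at the same place, and this one also stays within the scatter. Together with the earlier step, this means that three quite different groups on this carbonyl carbon (morpholin-4-yl, methyl and phenyl) cannot be told apart in this assay, although no evidence is available to explain the result.

The compounds shown leave open whether any group on this carbonyl carbon can move the number beyond the scatter, for example a chain ending in an amine, a carboxylic acid or a longer chain such as hexyl. They also leave open whether morpholin-4-yl, methyl and phenyl would remain indistinguishable at this place in a different kind of test, since every step here comes from the same cell assay.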